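The source may report more compounds than this note shows. Statements on the series, on what has been measured and on what is new or still open speak of the compounds shown alone.

Of the compounds shown here, three built on a shared core have been tested in a functional assay on PC-3M cells (Homo sapiens) for cytotoxicity, read by MTT assay, with a stated time of 48 h (a lower number here means a stronger inhibitor, a higher number a weaker inhibitor), and none of them gave a number. Compound 1 `Cc1nnc(SCC(=O)c2ccccc2)n1N1C(=O)c2ccccc2C1=O` reaches only the limit of this assay, > 200000 nM. Compound 2 `CCc1nnc(SCc2ccccc2)n1N1C(=O)c2ccccc2C1=O` likewise returns nothing more than a limit, > 200000 nM. Compound 3 `COc1cc(-c2nnc(SC)n2N2C(=O)c3ccccc3C2=O)cc(OC)c1OC`, which carries a methylsulfanyl group, also ends at a limit, > 200000 nM. So compound 3 stands where the other two stand: all three values sit at the limit of > 200000 nM in this assay, at which 3 of the 3 values shown sit, and nothing among them can be ranked.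

Going by the values given here, compound 4 `COc1cc(-c2nnc(SCC(=O)c3ccccc3C)n2N2C(=O)c3ccccc3C2=O)cc(OC)c1OC` is the one change from compound 3 that is not yet measured: (2-methylphenyl)carbonyl in place of hydrogen on a saturated chain carbon bound to a sulfur. Among the compounds with values here, no measured pair of this kind exists here, so the size of the step must be guessed. The closest hint is compound 1, whose sulfur also bears a carbonyl-linked aromatic ring on the chain carbon and which in this assay gives > 200000 nM, a limit. That makes a large gain for compound 4 seem unlikely. Compound 4 is therefore expected to land at about 250000 nM, in a range from 60000 nM to 1000000 nM, most probably again reported as a limit rather than a number. This estimate means an expected step that the limit leaves unreadable from compound 3 to compound 4, that is, no change beyond the usual scatter.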

Compound 4, half-maximal inhibitory concentration: > 200000 nM
Compound 4: a limit, no number; the forecaster's own chance of this, stated with the estimate: 85%; the middle value is on the limit's open side.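

Compound 3 and compound 4 both end at a limit rather than a number, so no step between them can be read: the limit of > 200000 nM in this assay, at which 4 of the 4 values shown sit.

The compounds shown leave open what effect, if any, (2-methylphenyl)carbonyl has on a saturated chain carbon bound to a sulfur, and whether any compound on this shared core gives a measurable value in this assay.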